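A Fluorine Swap Tested Against a Phosphatase Inhibition Limit

The source may report more compounds than this note shows. Statements on the series, on what has been measured and on what is new or still open speak of the compounds shown alone.

Among the measured compounds shown here, compound 1 `COc1ccccc1/C=C1\NS(=O)(=O)c2ccccc2C1=O` is the only compound here with a definite number: in an assay for inhibition of alkaline phosphatase, tissue-nonspecific isozyme (Homo sapiens), read by spectrophotometry, with stated times of 10 min and 20 min (on this read-out lower numbers stand for stronger inhibition and higher numbers for weaker inhibition), compound 1 gives 2590 nM. Compound 2 `O=C1/C(=C/c2ccccc2Br)NS(=O)(=O)c2ccccc21` in this assay gives > 200000 nM, which is a limit of the assay and not a number. Compound 3 `O=C1/C(=C/c2ccc(Cl)cc2Cl)NS(=O)(=O)c2ccccc21` in this assay likewise gives > 200000 nM, again a limit. For the measured compounds named here, the single measured step, an at least 77-fold higher number from compound 1 to compound 2 (1.88 log units; beyond the scatter), shows a large loss of inhibition. Compound 2 therefore stands at the limit of > 200000 nM in this assay, at which 2 of the 3 values shown sit, alongside compound 3, while compound 1 stands clearly stronger.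

Compound 4 `O=C1/C(=C/c2cccc(F)c2)NS(=O)(=O)c2ccccc21` has not yet been measured. It differs from compound 2 by 3-fluorophenyl in place of 2-bromophenyl on a double-bonded chain carbon bound to a double-bonded ring carbon. Going by the values given here, no measured step covers an exchange of one halogen-bearing phenyl for another; the step from compound 1 to compound 2 concerns bromo replacing methoxy, and compound 2 and compound 3, each carrying halogen, both sit at the limit. The expected step of an at least 1.3-fold lower number from compound 2 to compound 4 (0.12 log units; that floor lies within the scatter) is thus uncertain and may not exceed the scatter. For compound 4 the estimated value in this assay is 150000 nM, with an expected range from 30000 nM to 400000 nM.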

Compound 4, half-maximal inhibitory concentration: 3190 nM
For compound 4 the middle estimate is 47-fold (1.67 log units) above the measured one, outside the stated range (below it).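

In this assay, exchanging one halogen-bearing phenyl for another at this place gives an at least 62-fold lower number from compound 2 to compound 4 (1.79 log units; beyond the scatter), so the place tolerates a halogen-bearing phenyl and still responds strongly to which one it carries. Compound 2 and compound 3 might have suggested that any halogen on this phenyl ends inhibition, but compound 4 goes against that reading. From the compounds shown here alone, the value of compound 2 is a limit of the assay and not a number, so the step has only a floor, and its full size stays unknown: the limit of > 200000 nM in this assay, at which 2 of the 4 values shown sit.

The step changes both the halogen and the name's position number at once, so a comparison with 3-bromophenyl or 2-fluorophenyl would be needed to tell which of the two matters. Also open, going by these compounds, is how a phenyl carrying an amine or a carboxylic acid would read at this place.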